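Notes on the carbonyl substituent in the benzoxazole series

This account rests on a few compounds, and the source may have more. Where it says the series, first, only, none or still open, it means among the compounds named here.

Two compounds carry measurements. Compound 1 `CCCCN(c1nc2c(C(=O)O)cccc2o1)[C@H](C)c1ccc(-c2ccccc2-c2nnn[nH]2)cc1` gives 429 ng.h/mL in an ADME assay on the whole organism (Macaca fascicularis) for pharmacokinetics, read by LC-MS, using cassette dosing, at a dose of 1 mg/kg by the oral route; a higher number here means more compound in the circulation at the dose given, a lower number less compound in the circulation. Among the compounds with values here, compound 2 `CCCCN(c1nc2c(C(=O)NS(C)(=O)=O)cccc2o1)[C@H](C)c1ccc(-c2ccccc2-c2nnn[nH]2)cc1` gives 22.2 ng.h/mL in this assay, the lowest of the two numbers measured; the only step measured, a 19-fold lower number from compound 1 to compound 2 (1.29 log units; beyond the scatter), shows that exchange at this carbonyl carbon moves the read-out strongly. Compound 3 `CCCCN(c1nc2c(C(=O)N(C)C)cccc2o1)[C@H](C)c1ccc(-c2ccccc2-c2nnn[nH]2)cc1` differs from compound 2 by dimethylamino in place of methanesulfonamido on a carbonyl carbon. Within the data shown here, no measured step covers this exchange; the step from compound 1 to compound 2 bears on it only in showing that the carbonyl substituent matters, and it does not indicate the direction for compound 3. The expectation is therefore a wide one, centred above compound 2, with a step of a 4.5-fold higher number from compound 2 to compound 3 (0.65 log units; beyond the scatter) expected in this assay. For compound 3 the estimate in this assay is 100 ng.h/mL, expected to fall between 20 ng.h/mL and 500 ng.h/mL.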

Compound 3, area under the concentration-time curve: 104 ng.h/mL
For compound 3 the middle estimate is 1.0-fold (0.02 log units) below the measured one; the measured number falls inside the stated range.
By their numbers in this assay, from the lowest: compound 2; then compound 3; then compound 1.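

In this assay the step of a 4.7-fold higher number from compound 2 to compound 3 (0.67 log units; beyond the scatter) comes with dimethylamino in place of methanesulfonamido, and the step of a 4.1-fold lower number from compound 1 to compound 3 (0.62 log units; beyond the scatter) comes with dimethylamino in place of hydroxy. This carbonyl carbon therefore now shows three separate levels, with hydroxy in compound 1 highest, dimethylamino in compound 3 intermediate and methanesulfonamido in compound 2 lowest, and every step among them lies beyond the scatter. No available evidence accounts for this order.

Still open, as far as these compounds go, is where a primary carboxamide, a methylamino group or a longer chain such as diethylamino would fall on this carbonyl carbon. Also open, from the compounds shown here alone, is whether benzenesulfonamido would stay as low as the methanesulfonamido of compound 2, or whether that low level belongs to the methanesulfonamido group alone.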